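Swapping Methyl for Chloro on the Shared Core

The source may hold more compounds than are shown below. What is called first, only, known or untested is meant among the compounds shown, and "the series" means these compounds.

Compound 1 `Cc1ccc2[nH]c(-n3[nH]c(C)c(Cc4ccccc4)c3=O)nc2c1` is the reference point. In an assay on isolated protein for inhibition of alpha-ketoglutarate-dependent dioxygenase alkB homolog 3 (Homo sapiens), read by polymerase chain reaction, with a stated time of 1 h (a lower number here means a stronger inhibitor, a higher number a weaker inhibitor), compound 1 gives 670 nM, the lowest of the three numbers, though all three lie within the scatter of one another: compound 2 `Cc1ccc2[nH]c(-n3[nH]c(C)c(Cc4ccc(Cl)cc4)c3=O)nc2c1` gives 750 nM and compound 3 `Cc1ccc2[nH]c(-n3[nH]c(C)c(Cc4ccc(Cl)c(Cl)c4)c3=O)nc2c1` gives 720 nM. The measured steps of a 1.1-fold higher number from compound 1 to compound 2 (0.05 log units; within the scatter), a 1.1-fold higher number from compound 1 to compound 3 (0.03 log units; within the scatter) and a 1.0-fold lower number from compound 2 to compound 3 (0.02 log units; within the scatter) all concern the phenyl on the saturated chain carbon, and none of them moves the number beyond the scatter.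

Compound 4 `Cc1[nH]n(-c2nc3cc(Cl)ccc3[nH]2)c(=O)c1Cc1ccccc1` differs from compound 1 in one place: chloro in place of methyl on an aromatic carbon. For the measured compounds named here, no measured step touches this part of the shared core, so the data give no direct guide to how the number should move. The only hint is that adding chloro on the phenyl left the number within the scatter. The expectation for compound 4 is therefore a step of a 1.0-fold higher number from compound 1 to compound 4 (0.02 log units; within the scatter), no larger than the scatter, giving an estimated 700 nM with a range of 350 nM to 1400 nM.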

Compound 4, half-maximal inhibitory concentration: 4500 nM
Compound 4: the middle estimate sits 6.4-fold (0.81 log units) below what was measured; measured number above the stated range.
By their numbers in this assay, from the lowest: compounds 1, 3 and 2 (each within the scatter of the next); then compound 4.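

Swapping methyl for chloro on this aromatic carbon of the shared core gives a 6.7-fold higher number from compound 1 to compound 4 (0.83 log units; beyond the scatter) in this assay, making compound 4 a weaker inhibitor than compound 1. This is the first step shown to go beyond the scatter, so this position responds to a change of a single heavy atom, whereas adding chloro on the phenyl gave only a 1.1-fold higher number from compound 1 to compound 2 (0.05 log units; within the scatter) and stayed within the scatter. Nothing available explains why this swap moves the number so much.

As far as these compounds go, it remains open whether the step comes from losing the methyl or from gaining the chloro. A compound with hydrogen, fluoro, ethyl or methoxy on this same carbon would help separate the two and show how much change this position tolerates.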